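Removing the chloro from the anilino ring of compound 2

This account rests on a few compounds, and the source may have more. Where it says the series, first, only, none or still open, it means among the compounds named here.

Compound 1: `Cc1ccc(Nc2nc(Cl)nc3c2ncn3Cc2ccc(/C=C/C(=O)Nc3ccccc3N)cc2)cc1` — 51.3%
Compound 2: `Nc1ccccc1NC(=O)/C=C/c1ccc(Cn2cnc3c(Nc4cccc(Cl)c4)nc(Cl)nc32)cc1` — 29.4%
Compound 3: `Nc1ccccc1NC(=O)c1ccc(Cn2cnc3c(Nc4cccc(Cl)c4)nc(Cl)nc32)cc1` — 67%

In a functional assay on NCI-H460 cells (Homo sapiens) for antiproliferative activity, read by CCK-8 assay, with a stated time of 72 h, tested at 8 uM (a higher number here means a stronger effect of the compound at the concentration tested, a lower number a weaker effect), compound 2 gives 29.4%, the lowest of the three numbers measured. Where compound 2 carries a 3-chlorophenyl, compound 1 carries a 4-methylphenyl, and compound 1 gives 51.3%. Compound 3 carries the (2-aminophenyl)carbamoyl in place of the 2-((2-aminophenyl)carbamoyl)ethenyl, and compound 3 gives 67%.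

Compound 4, `Nc1ccccc1NC(=O)/C=C/c1ccc(Cn2cnc3c(Nc4ccccc4)nc(Cl)nc32)cc1`, is not yet measured. It differs from compound 2 by hydrogen in place of chloro on an aromatic carbon. Among the compounds with values here, the only measured step that touches this part of the molecule is a number 21.9 percentage points lower from compound 1 to compound 2 (beyond the scatter), where the arrival of the 3-chlorophenyl coincided with a modest fall. The step of a number 37.6 percentage points higher from compound 2 to compound 3 (beyond the scatter) alters another part of the molecule and says nothing about the chloro. Taking away the chloro is therefore expected to move the number back up modestly, though with a wide range, since no measured pair shows this exact change. Compound 4 is expected to give 40%, between 25% and 58%, which means an expected step of a number 10.6 percentage points higher from compound 2 to compound 4 (beyond the scatter).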

Compound 4, a percentage reported as inhibition, at one concentration (the size of the read-out at that concentration, not a potency): 28.7%
The estimate for compound 4 lay 11.3 percentage points above the measured number; the measured number falls inside the stated range.
By their numbers in this assay, from the lowest: compounds 4 and 2 (each within the scatter of the next); then compound 1; then compound 3.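

In this assay, the step of a number 0.7 percentage points lower from compound 2 to compound 4 (within the scatter) shows that replacing the chloro of the 3-chlorophenyl with hydrogen leaves the read-out within the scatter, so the chloro does not account for the gap between compound 1 and compound 2. The step of a number 22.6 percentage points lower from compound 1 to compound 4 (beyond the scatter) points instead to the methyl of the 4-methylphenyl: among these three compounds, phenyl and 3-chlorophenyl read alike, and only the 4-methylphenyl stands apart. Nothing available explains why the methyl makes this difference.

On these data alone, it remains open whether a methoxy or an amine in place of that methyl would read like the methyl or like hydrogen. As far as these compounds go, it is also open whether the 4-methylphenyl would keep its advantage alongside the (2-aminophenyl)carbamoyl of compound 3, and how any of this translates to potency, since the read-out comes from one concentration.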